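The source may report more compounds than this note shows. Statements on the series, on what has been measured and on what is new or still open speak of the compounds shown alone.

Measured compounds in a functional assay on Ehrlich cells (Mus musculus) for antiproliferative activity, read by trypan blue exclusion, with a stated time of 2 h, tested at 50 ug/mL; a higher number here means a stronger effect of the compound at the concentration tested, a lower number a weaker effect:
Compound 1 `COc1ccccc1C1C(C#N)=C(N)N(c2ccc(S(N)(=O)=O)cc2)C2=C1C(=O)CCC2` gives 0%.
Compound 2 `COc1ccc(C2C(C#N)=C(N)N(c3ccc(S(N)(=O)=O)cc3)C3=C2C(=O)CCC3)cc1` gives 90%.
Compound 3 `N#CC1=C(N)N(c2ccc(S(N)(=O)=O)cc2)C2=C(C(=O)CCC2)C1c1cccc([N+](=O)[O-])c1` gives 73%.

Compound 1 stands lowest of the three numbers; compound 3 is nearest to it and compound 2 furthest, and both gaps lie far beyond the usual scatter. Compound 4 `Cc1ccoc1C1C(C#N)=C(N)N(c2ccc(S(N)(=O)=O)cc2)C2=C1C(=O)CCC2` has not yet been measured. It differs from compound 1 in one place: 3-methylfuran-2-yl in place of 2-methoxyphenyl on a saturated ring carbon. Two measured steps start from compound 1 and change the same group: a number 90 percentage points higher from compound 1 to compound 2 (beyond the scatter) and a number 73 percentage points higher from compound 1 to compound 3 (beyond the scatter). Both replace the 2-methoxyphenyl group on the same saturated ring carbon, and both show a large rise. Neither of them, however, brings in a five-membered aromatic ring with one hetero atom; the entering 3-methylfuran-2-yl is a different kind of ring from 4-methoxyphenyl or 3-nitrophenyl, so these two steps bear on the new one only indirectly. Both measured steps point the same way, so for compound 4 a rise beyond the scatter is expected, with wide uncertainty, and the expected step is a number 50 percentage points higher from compound 1 to compound 4 (beyond the scatter). Compound 4 is therefore estimated at 50%, within a range from 5% to 90%.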

Compound 4, a percentage reported as activity, at one concentration (the size of the read-out at that concentration, not a potency): 40%
Compound 4: middle estimate off by 10 percentage points, on the high side; the range from low to high includes it.
By their numbers in this assay, from the lowest: compound 1; then compound 4; then compound 3; then compound 2.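

In this assay the step of a number 40 percentage points higher from compound 1 to compound 4 (beyond the scatter) shows that the rise on leaving 2-methoxyphenyl at this saturated ring carbon does not depend on keeping a six-membered aromatic ring of carbon only, as 3-methylfuran-2-yl brings a five-membered aromatic ring with 1 hetero atom and still lifts the read-out. The same group falls short of both six-membered rings, with a number 33 percentage points lower from compound 3 to compound 4 (beyond the scatter) and also a number 50 percentage points lower from compound 2 to compound 4 (beyond the scatter), so among these four compounds the group at this one carbon gives a graded series of read-outs, not a simple split into active and inactive. No measurement offered here accounts for this order.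

The compounds shown leave open what part of the result belongs to the methyl group and what part to the furan ring, and a plain furan-2-yl or a thiophen-2-yl group at the same carbon would help to separate the two. Going by these compounds, each number is also a read-out at a single concentration, so how the four compounds would compare in potency remains unknown.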